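A further bromo on compound 2

The compounds below may be only part of what the source reports. "The series", "measured", "known", "first", "only" and "open" are said of these compounds alone.

In a functional assay (Mus musculus, strain BALB/C) for inhibition, read by MTT assay, with stated times of 24 h and 72 h (on this read-out higher numbers stand for weaker inhibition and lower numbers for stronger inhibition), compound 1 (`Cc1ccc(C(=O)N/N=C/c2cc(Cl)ccc2O)c(O)c1`) gives 1290 nM and compound 2 (`Cc1ccc(C(=O)N/N=C/c2cc(Br)ccc2O)c(O)c1`) gives 1090 nM, so compound 2 stands level with compound 1 within the scatter. For the measured compounds named here, the only measured step, a 1.2-fold lower number from compound 1 to compound 2 (0.07 log units; within the scatter), exchanges chloro for bromo and adds no group, so it bears only loosely on what follows. Compound 3 (`Cc1ccc(C(=O)N/N=C/c2cc(Br)cc(Br)c2O)c(O)c1`) differs from compound 2 by bromo in place of hydrogen on an aromatic carbon. No step beyond the scatter is expected in this assay. The estimated change is a 1.2-fold lower number from compound 2 to compound 3 (0.08 log units; within the scatter). For compound 3 the expected value is 900 nM, within an estimated range of 350 nM to 2300 nM.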

Compound 3, half-maximal inhibitory concentration: 2020 nM
Estimate against measurement, compound 3: 2.2-fold (0.35 log units) below, within the range that was stated.
By their numbers in this assay, from the lowest: compounds 2, 1 and 3 (each within the scatter of the next).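

With the existing bromo left in place, a further bromo in place of hydrogen, ortho to a hydroxy group and meta to a bromo group, gives a 1.9-fold higher number from compound 2 to compound 3 (0.27 log units; within the scatter) in this assay. The earlier compounds shown here showed only one halogen exchanged for another at an already occupied place; here an unoccupied place on the ring takes a bromo with no step beyond the scatter. Nothing available gives a reason for this result.

From the compounds shown here alone, whether an amine, a methoxy group or a carboxylic acid at this same place would also stay within the scatter remains open. So does whether a single bromo here, without the other bromo, would behave like compound 3.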